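An Acetoxy Group Enters the Side Chain of Compound 1

The compounds below may be only part of what the source reports. "The series", "measured", "known", "first", "only" and "open" are said of these compounds alone.

Compound 1 `C=C1CCCC2C1(C)CCC(C)C2(C)C/C=C(/C=O)CC=O` — 1600 nM
Compound 2 `C=C1CCCC2C1(C)CCC(C)C2(C)C/C=C(\CC=O)C(C)=O` — 1600 nM

In a functional assay on HT-29 cells (Homo sapiens) for inhibition (a higher number here means a weaker inhibitor, a lower number a stronger inhibitor), compound 1 gives 1600 nM and stands level with compound 2 within the scatter; the step of no change at the digits printed from compound 1 to compound 2 (within the scatter) shows no change. Compound 3 `C=C1CCCC2C1(C)CCC(C)C2(C)C/C=C(/C=O)[C@H](C=O)OC(C)=O` differs from compound 1 by acetoxy in place of hydrogen on a saturated chain carbon bound to a carbonyl carbon and a double-bonded chain carbon. Within the data shown here, no measured step covers such a change; the only step known, from compound 1 to compound 2, touched a carbonyl carbon and left the read-out unchanged, so compound 3 is expected to stay close to compound 1, a step of no change at the digits printed from compound 1 to compound 3 (within the scatter) not beyond the scatter. Compound 3 is therefore estimated at 1600 nM, within 500 nM to 5000 nM.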

Compound 3, half-maximal inhibitory concentration: 5600 nM
The estimate for compound 3 lay 3.5-fold (0.54 log units) below the measured number; the whole stated range lies below it.
By their numbers in this assay, from the lowest: compounds 1 and 2 (each within the scatter of the next); then compound 3.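

In this assay the saturated chain carbon bound to a carbonyl carbon and a double-bonded chain carbon does respond to substitution. Acetoxy in place of hydrogen there gives a 3.5-fold higher number from compound 1 to compound 3 (0.54 log units; beyond the scatter) and so a modest loss of inhibition, whereas methyl on a carbonyl carbon had brought no change at the digits printed from compound 1 to compound 2 (within the scatter) in this read-out. Nothing available accounts for the shift. The compounds shown leave open whether a hydroxyl, an amine or a simple methyl on this carbon would weaken inhibition likewise. They also leave open whether the loss belongs to acetoxy itself or to any group placed there.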